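Moving from pyridin-3-yl to pyridin-2-yl on the amide

The source may hold more compounds than are shown below. What is called first, only, known or untested is meant among the compounds shown, and "the series" means these compounds.

Three measured compounds share one core and differ only in the group on an amide-type nitrogen: compound 1 `CN1C[C@H](C(=O)Nc2cccc(Cl)c2)[C@@H](c2ccc(/C=C/C(=O)Nc3ccccc3N)cc2)C1`, compound 2 `CN1C[C@H](C(=O)Nc2ccc(F)c(Br)c2)[C@@H](c2ccc(/C=C/C(=O)Nc3ccccc3N)cc2)C1` and compound 3 `CN1C[C@H](C(=O)Nc2cccnc2)[C@@H](c2ccc(/C=C/C(=O)Nc3ccccc3N)cc2)C1`. In an in vitro ADME assay on microsomes from liver (Homo sapiens) for pharmacokinetics, read by LC-MS, with a stated time of 10 min, tested at 1 uM (a lower number here means slower removal, a higher number faster removal of the compound), compound 1 gives 7 mL/min/kg, compound 2 gives 15 mL/min/kg and compound 3 gives 10 mL/min/kg. Compound 3 therefore lies within the scatter of both others, with a 1.4-fold higher number from compound 1 to compound 3 (0.15 log units; within the scatter) and a 1.5-fold lower number from compound 2 to compound 3 (0.18 log units; within the scatter).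

Compound 4 `CN1C[C@H](C(=O)Nc2ccccn2)[C@@H](c2ccc(/C=C/C(=O)Nc3ccccc3N)cc2)C1` differs from compound 3 in one group: pyridin-2-yl in place of pyridin-3-yl on an amide-type nitrogen. Among the compounds with values here, the two groups have the same atoms, joined differently, and no measured pair makes this exact change. The closest guide is the set of steps at the same place, where replacing one whole group with another gave at most a modest step, a 2.1-fold higher number from compound 1 to compound 2 (0.33 log units; beyond the scatter). A change beyond the scatter is therefore not expected in this assay, and the expected step is no change at the digits printed from compound 3 to compound 4 (within the scatter). The estimated value for compound 4 is 10 mL/min/kg, with an expected range from 5 mL/min/kg to 20 mL/min/kg.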

Compound 4, clearance: 8 mL/min/kg
Estimate against measurement, compound 4: 1.3-fold (0.10 log units) above; low and high end bracket the measured number.
By their numbers in this assay, from the lowest: compounds 1, 4, 3 and 2 (each within the scatter of the next, the first and the last beyond it).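

Swapping pyridin-3-yl for pyridin-2-yl on an amide-type nitrogen keeps the same atoms and only joins them differently, and in this assay this gives a 1.3-fold lower number from compound 3 to compound 4 (0.10 log units; within the scatter). Compound 4 also stays within the scatter of both halogen-bearing compounds, with a 1.9-fold lower number from compound 2 to compound 4 (0.27 log units; within the scatter) and a 1.1-fold higher number from compound 1 to compound 4 (0.06 log units; within the scatter), even though compound 1 and compound 2 lie beyond the scatter of each other. Nothing measured here explains why these groups read alike.

Still open, going by these compounds, is whether pyridin-4-yl, a saturated piperidin-4-yl ring or a simple butyl chain on the same nitrogen would also stay within this narrow range in this assay. On these data alone, it is also open whether the swap between pyridin-3-yl and pyridin-2-yl would read the same with a different group in place of the methyl on the shared core.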